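Amino for hydrogen on a dichloro-derived purine series

The source may hold more compounds than are shown below. What is called first, only, known or untested is meant among the compounds shown, and "the series" means these compounds.

Measured compounds: compound 1 `ClCc1ccccc1Cn1cnc2c(Cl)nc(Cl)nc21`, 2950 nM; compound 2 `ClCc1ccccc1Cn1cnc2c(Cl)ncnc21`, 33100 nM; compound 3 `ClCc1ccccc1Cn1cnc2ncnc(Cl)c21`, 11200 nM.

In a functional assay on KM12 cells (Homo sapiens) for cytotoxicity, read by sulforhodamine B assay, with a stated time of 48 h (on this read-out lower numbers stand for stronger inhibition of growth and higher numbers for weaker inhibition of growth), compound 2 gives the highest of the three numbers, standing furthest from compound 1 and nearest to compound 3. Within the data shown here, the only single change measured, an 11-fold higher number from compound 1 to compound 2 (1.05 log units; beyond the scatter), shows that the carbon flanked by the two ring nitrogens matters. Compound 4 `Nc1nc(Cl)c2ncn(Cc3ccccc3CCl)c2n1` carries amino in place of hydrogen on an aromatic carbon. Among the measured compounds shown here, no measured step involves an amino group, so this change is not directly covered; the outcome is judged only from the sensitivity of that carbon seen in compound 1 against compound 2. Compound 4 is therefore expected to move by a 2.8-fold lower number from compound 2 to compound 4 (0.44 log units; beyond the scatter) in this assay, estimated at 12000 nM (range 2500 nM to 50000 nM).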

Compound 4, concentration for total growth inhibition: 38900 nM
For compound 4 the middle estimate is 3.2-fold (0.51 log units) below the measured one; measured number inside the range.
By their numbers in this assay, from the lowest: compound 1; then compound 3; then compounds 2 and 4 (each within the scatter of the next).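

In this assay, a group on the aromatic carbon between two ring nitrogen atoms does not by itself go with a lower number: amino and hydrogen cannot be told apart there, with a 1.2-fold higher number from compound 2 to compound 4 (0.07 log units; within the scatter). Chloro is what stands apart at this place, with a 13-fold higher number from compound 1 to compound 4 (1.12 log units; beyond the scatter), so the earlier gain belongs to chloro and not to any replacement of hydrogen. Nothing shown here offers an explanation for this.

The compounds shown leave open whether fluoro, bromo or methoxy at this carbon would group with chloro or with amino and hydrogen.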